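Swapping a Triazolylmethyl Arm for a Cyclic Urea

The source may report more compounds than this note shows. Statements on the series, on what has been measured and on what is new or still open speak of the compounds shown alone.

Measured compounds:
Compound 1, `CC(C)C(Cc1nnc[nH]1)c1ccc(-c2ccc3cccc(F)c3c2)[nH]c1=O`, gives 0.307 h in an ADME assay on microsomes from liver (Homo sapiens) for metabolic stability; on this read-out lower numbers stand for a shorter-lived compound and higher numbers for a longer-lived compound.
Compound 2, `CC(C)[C@H](C[C@H]1CCNC1=O)c1ccc(-c2ccc3cccc(F)c3c2)[nH]c1=O`, gives 0.257 h in this assay.
Compound 3, `CCC(CC)(c1nnc[nH]1)c1ccc(-c2ccc3cccc(F)c3c2)[nH]c1=O`, gives 1.19 h in this assay.

Among these three numbers compound 1 holds the second highest. Its nearest neighbour is compound 2, whose value lies within the usual scatter of compound 1, so the two cannot be told apart. Compound 3 stands furthest away, with a value beyond the scatter and clearly higher than that of compound 1.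

Compound 4, `CC(C)C(c1ccc(-c2ccc3cccc(F)c3c2)[nH]c1=O)N1CCNC1=O`, has not yet been measured. It differs from compound 1 in one place: 2-oxoimidazolidin-1-yl in place of (4H-1,2,4-triazol-3-yl)methyl on a saturated chain carbon bound to an aromatic carbon and a saturated chain carbon. The shared core and the side chain it sits on are otherwise unchanged.

Among the compounds with values here, no measured pair shows what this kind of change does in this assay, so the size of the step is uncertain. The expectation is a step of no more than the scatter in either direction, that is, from compound 1 to compound 4 roughly a 1.1-fold higher number from compound 1 to compound 4 (0.06 log units; within the scatter). On that basis compound 4 is estimated at 0.35 h in this assay, with a plausible range from 0.15 h to 0.9 h.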

Compound 4, half-life: 1.03 h
Compound 4: the middle estimate sits 2.9-fold (0.47 log units) below what was measured; measured number above the stated range.
By their numbers in this assay, from the lowest: compounds 2 and 1 (each within the scatter of the next); then compounds 4 and 3 (each within the scatter of the next).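

In this assay the carbon bound to an aromatic carbon and a saturated chain carbon proves sensitive to what it carries: placing 2-oxoimidazolidin-1-yl there instead of (4H-1,2,4-triazol-3-yl)methyl gives a 3.4-fold higher number from compound 1 to compound 4 (0.53 log units; beyond the scatter) and this step lies beyond the usual scatter. Each group has 6 heavy atoms, so for this pair the number of heavy atoms does not settle the half-life, while a five-membered aromatic ring with 3 hetero atoms gives way to a five-membered non-aromatic ring with 2 hetero atoms. No measurement shown here gives a reason for the step.

The swap changes the ring and also removes the methyl link, so the compounds shown leave open which of the two carries the step, and a (2-oxoimidazolidin-1-yl)methyl group on the same carbon would separate them. Also open, going by these compounds, is whether the ring matters at all, which an open-chain urea or a simple acetamide at this place could show.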